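Trimming the Amide Cap in a Kinase Inhibitor Pair

The source may report more compounds than this note shows. Statements on the series, on what has been measured and on what is new or still open speak of the compounds shown alone.

Measured compounds:
compound 1, `COc1ncc(N2CCc3ncnc(O[C@H]4CCN(C(=O)C5CCOCC5)C4)c3C2)cc1C(F)(F)F`, 3580 nM
compound 2, `COc1ncc(N2CCc3ncnc(O[C@H]4CCN(C(=O)C5CCOCC5)C4)c3C2)cc1C`, 6790 nM

Both compounds were tested in an ADME assay on Rat1 cells for inhibition of phosphatidylinositol 4,5-bisphosphate 3-kinase catalytic subunit beta isoform (Homo sapiens), with a stated time of 1 h; on this read-out higher numbers stand for weaker inhibition and lower numbers for stronger inhibition. Compound 1 gives 3580 nM and compound 2 gives 6790 nM. Going by the values given here, the only measured step, a 1.9-fold higher number from compound 1 to compound 2 (0.28 log units; within the scatter), places the two compounds within the scatter of one another, so compound 1 cannot be called stronger than compound 2 on these numbers.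

Compound 3, `CCC(=O)N1CC[C@H](Oc2ncnc3c2CN(c2cnc(OC)c(C(F)(F)F)c2)CC3)C1`, has not yet been measured. It differs from compound 1 in a single place: ethyl in place of oxan-4-yl on a carbonyl carbon. Among the compounds with values here, no measured step touches this part of the molecule; the one step on record, a 1.9-fold higher number from compound 1 to compound 2 (0.28 log units; within the scatter), concerns the substituent on the aromatic carbon of the methoxypyridine side and so gives no direct guide. In the absence of any relevant step, the shared core and the remaining substituents being identical, the estimate for compound 3 rests on compound 1 alone. The step from compound 1 to compound 3 is expected to be a 1.1-fold higher number from compound 1 to compound 3 (0.05 log units; within the scatter), that is, nothing beyond the scatter. Compound 3 is therefore estimated at 4000 nM, with a range from 1500 nM to 11000 nM.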

Compound 3, half-maximal inhibitory concentration: 3110 nM
Beside the measured number, compound 3's estimate is 1.3-fold (0.11 log units) above it, within the range that was stated.
By their numbers in this assay, from the lowest: compounds 3, 1 and 2 (each within the scatter of the next, the first and the last beyond it).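

In this assay, ethyl in place of oxan-4-yl on the carbonyl carbon gives a 1.2-fold lower number from compound 1 to compound 3 (0.06 log units; within the scatter), so the two compounds cannot be told apart on this read-out. Going by these compounds alone, the earlier pair differed only in the substituent on the aromatic carbon, whereas this result is the first reading at the amide cap: here the oxan-4-yl ring and its hydrogen-bond acceptor can be exchanged for an open ethyl group without moving the number beyond the scatter. The data shown offer no measurement that would explain this outcome.

As far as these compounds go, what remains open is whether this tolerance extends to groups of a different kind on the same carbonyl carbon, such as a longer chain, a primary amine or a carboxylic acid, any of which might separate from compound 1 where ethyl does not. From the compounds shown here alone, it is also open whether the propanoyl cap of compound 3 would behave the same way with methyl in place of trifluoromethyl on the aromatic carbon, since the two positions have so far been varied only one at a time.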